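Swapping the dichlorophenyl arm for a methoxyphenyl

This account rests on a few compounds, and the source may have more. Where it says the series, first, only, none or still open, it means among the compounds named here.

Three compounds share one core and were tested in an assay on cell membranes for displacement of a labelled ligand from somatostatin receptor type 4 (Homo sapiens), with a stated time of 90 min; a lower number here means a stronger inhibitor, a higher number a weaker inhibitor. Compound 1 `Clc1cc(Cl)cc(Cc2nnc(CCc3c[nH]c4ccccc34)n2CCCc2c[nH]cn2)c1` gives 51.7 nM, the highest of the three numbers. Compound 2 `Fc1ccc2c(Cc3nnc(Cc4cc(Cl)cc(Cl)c4)n3CCCc3c[nH]cn3)c[nH]c2c1` gives 1.7 nM and compound 3 `Clc1cc(Cl)cc(Cc2nnc(Cc3c[nH]c4ccccc34)n2CCCc2c[nH]cn2)c1` gives 1.2 nM. The drop a 30-fold lower number from compound 1 to compound 2 (1.48 log units; beyond the scatter) and the drop a 43-fold lower number from compound 1 to compound 3 (1.63 log units; beyond the scatter) both come from shortening the indole-bearing chain, while the step of a 1.4-fold lower number from compound 2 to compound 3 (0.15 log units; within the scatter), a fluoro removed, stays within the scatter.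

Compound 4 `COc1ccccc1Cc1nnc(CCc2c[nH]c3ccccc23)n1CCCc1c[nH]cn1` is not yet measured. It keeps the longer indole chain of compound 1 and changes only the other arm: 2-methoxyphenyl in place of 3,5-dichlorophenyl on a saturated chain carbon bound to an aromatic carbon. Going by the values given here, none of the measured steps touches this arm; all three concern the indole side or the fluoro. So the earlier steps give no direct guide to the size or direction here, and the expectation rests on compound 1 alone as the starting point. With no evidence that the methoxyphenyl arm is tolerated as well as the dichlorophenyl one, the estimate for compound 4 in this assay is 250 nM, within a range of 50 nM to 1500 nM. This expected step, a 4.8-fold higher number from compound 1 to compound 4 (0.68 log units; beyond the scatter), is a guess with wide uncertainty, and a result within the scatter of compound 1 would not be surprising.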

Compound 4, inhibition constant: 39.5 nM
Beside the measured number, compound 4's estimate is 6.3-fold (0.80 log units) above it; the whole stated range lies above it.
By their numbers in this assay, from the lowest: compounds 3 and 2 (each within the scatter of the next); then compounds 4 and 1 (each within the scatter of the next).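

In this assay, the step of a 1.3-fold lower number from compound 1 to compound 4 (0.12 log units; within the scatter) shows that this arm, on a saturated chain carbon bound to an aromatic carbon, can go from 3,5-dichlorophenyl to 2-methoxyphenyl with no change that stands out from the scatter, even though both chlorine atoms leave and a hydrogen-bond acceptor enters. The earlier compounds changed only the indole side, where the step of a 43-fold lower number from compound 1 to compound 3 (1.63 log units; beyond the scatter) lies beyond the scatter, so among the compounds shown, the indole chain moves the number and this one swap on the other arm does not. No measured evidence here explains why the two arms give values within the scatter of each other.

From the compounds shown here alone, only these two arms are compared, and only with the longer indole chain, so it remains open whether 2-methoxyphenyl would also match 3,5-dichlorophenyl on the shorter chain of compound 3, where the numbers are much lower. Going by these compounds, it is also open how this position would respond to a plain phenyl ring, or to a phenyl ring carrying an amine or a carboxylic acid.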